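The compounds below may be only part of what the source reports. "The series", "measured", "known", "first", "only" and "open" are said of these compounds alone.

In a functional assay on K562 cells (Homo sapiens) for cytotoxicity, read by sulforhodamine B assay, with a stated time of 48 h, tested at 0.01 uM (a higher number here means a weaker effect of the compound at the concentration tested, a lower number a stronger effect), compound 1 `COc1cc(-c2cc(/C=C/C(=O)c3ccc(Cl)c(Cl)c3)[nH]n2)cc(OC)c1OC` gives 99%. Compound 2 `COc1ccc(C(=O)/C=C/c2cc(-c3cc(OC)c(OC)c(OC)c3)n[nH]2)cc1OC` gives 96% in this assay, and it stands alongside compound 1, the two numbers lying within the scatter of each other; the step of a number 3 percentage points lower from compound 1 to compound 2 (within the scatter) confirms this. Compound 3 `COc1cc(-c2cc(/C=C/C(=O)c3ccc(F)c(F)c3)[nH]n2)cc(OC)c1OC` differs from compound 2 in one place: 3,4-difluorophenyl in place of 3,4-dimethoxyphenyl on a carbonyl carbon. Within the data shown here, the only step that bears on this, the exchange on the same carbonyl carbon from compound 1 to compound 2, stayed within the scatter, so the expected step of a number 1 percentage points higher from compound 2 to compound 3 (within the scatter) is none beyond the scatter. Compound 3 is therefore estimated at 97%, within 88% to 104%.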

Compound 3, a percentage reported as activity, at one concentration (the size of the read-out at that concentration, not a potency): 100%
Compound 3: middle estimate off by 3 percentage points, on the low side; low and high end bracket the measured number.
By their numbers in this assay, from the lowest: compounds 2, 1 and 3 (each within the scatter of the next).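

In this assay, the exchange for 3,4-difluorophenyl on the carbonyl carbon gives a number 4 percentage points higher from compound 2 to compound 3 (within the scatter) and a number 1 percentage points higher from compound 1 to compound 3 (within the scatter). With this third group, no exchange at this position yet shows a step beyond the scatter, whether the phenyl ring carries methoxy, chlorine or fluorine groups. No measurement is available that offers an explanation for this.

On these data alone, whether these groups would separate at other concentrations remains open. Also open, as far as these compounds go, is what a phenyl ring carrying an amine or a carboxylic acid would do on this carbonyl carbon.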